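Dropping a Methyl From the Methoxy Arm

The compounds below may be only part of what the source reports. "The series", "measured", "known", "first", "only" and "open" are said of these compounds alone.

Measured so far in a functional assay on HCT-15 cells (Homo sapiens) for cytotoxicity; a higher number here means a weaker inhibitor of growth, a lower number a stronger inhibitor of growth:
- compound 1, `OCCCCC#Cc1ccccc1C#Cc1ccccn1`: 29800 nM
- compound 2, `OCCCCC#Cc1ccccc1C#Cc1cccs1`: 13100 nM
- compound 3, `COc1cccc(C#Cc2ccccc2C#CCCCCO)c1`: 3600 nM

Compound 3 gives the lowest number of the three, with compound 2 nearest and compound 1 furthest away, both gaps beyond the scatter. Among the compounds with values here, the only single-point step so far is a 2.3-fold lower number from compound 1 to compound 2 (0.36 log units; beyond the scatter), which swaps one ring for another on the triple-bonded carbon.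

Compound 4, `OCCCCC#Cc1ccccc1C#Cc1cccc(O)c1`, is reached from compound 3 by hydrogen in place of methyl on an oxygen on an aromatic ring. Within the data shown here, no measured step changes a small substituent on a ring in this way; the step from compound 1 to compound 2 touches the same end of the molecule but replaces a whole ring, so it only suggests that changes there move the number modestly. A step within the scatter or a modest shift in either direction in this assay is therefore expected, with no strong lean.

Compound 4 is expected to give 5000 nM, within 1500 nM to 16000 nM. This estimate corresponds to an expected step of a 1.4-fold higher number from compound 3 to compound 4 (0.14 log units; within the scatter).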

Compound 4, concentration for 50% growth inhibition: 13600 nM
Estimate against measurement, compound 4: 2.7-fold (0.43 log units) below; the range from low to high includes it.
By their numbers in this assay, from the lowest: compound 3; then compounds 2 and 4 (each within the scatter of the next); then compound 1.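

In this assay, within the data shown here, this is the first step that changes only a small substituent on the ring, and losing one methyl from the oxygen is not neutral: methoxy to hydroxy gives (a 3.8-fold higher number from compound 3 to compound 4 (0.58 log units; beyond the scatter)). The advantage of compound 3 disappears with that one carbon, as 3-hydroxyphenyl in place of thiophen-2-yl gives (a 1.0-fold higher number from compound 2 to compound 4 (0.02 log units; within the scatter)), while 3-hydroxyphenyl in place of pyridin-2-yl still gives (a 2.2-fold lower number from compound 1 to compound 4 (0.34 log units; beyond the scatter)). So a change of one carbon on this ring can move the number about as far as replacing the whole ring, though no available data account for this step.

As far as these compounds go, whether an ethoxy group on the same oxygen would keep the lower number remains open, as does how an amine or a carboxylic acid would behave in place of the hydroxy. The alcohol-bearing chain at the other end is the same in all four compounds, so the effect of a longer chain there is also unknown.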